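Growth inhibition notes: replacing (furan-2-yl)methyl on the amine nitrogen

A few compounds are considered here, and "the series" means these few. Any claim that something is new, unique, unknown or untested is made for them only; others in the source may bear on it.

Values in a functional assay on MDA-MB-231 cells (Homo sapiens) for inhibition, read by CCK-8 assay, with a stated time of 48 h (a lower number here means a stronger inhibitor of growth, a higher number a weaker inhibitor of growth), follow.
- compound 1 `Cc1ccc(CNc2nc(Nc3ccc(N4CCN(C)CC4)cn3)ncc2Cl)cc1` gives 18600 nM
- compound 2 `COc1cccc(CNc2nc(Nc3ccc(N4CCN(C)CC4)cn3)ncc2Cl)c1` gives 20300 nM
- compound 3 `CN1CCN(c2ccc(Nc3ncc(Cl)c(NCc4ccco4)n3)nc2)CC1` gives 11000 nM

Compound 3 stands level with the other two, with a 1.7-fold lower number from compound 1 to compound 3 (0.23 log units; within the scatter) and a 1.8-fold lower number from compound 2 to compound 3 (0.27 log units; within the scatter) as its steps. Compound 4 `Cc1cc(C)c(Nc2nc(Nc3ccc(N4CCN(C)CC4)cn3)ncc2Cl)c(C)c1` puts 2,4,6-trimethylphenyl in place of (furan-2-yl)methyl on a nitrogen on an aromatic ring. The closest evidence is the exchanges on the saturated chain carbon, namely those two steps and a 1.1-fold higher number from compound 1 to compound 2 (0.04 log units; within the scatter) as well. Going by the values given here, none of them removes that chain carbon, so no measured step covers this change directly. In this assay no shift beyond the scatter is expected, with a 1.3-fold higher number from compound 3 to compound 4 (0.10 log units; within the scatter) as the estimated step. Compound 4 is estimated at 14000 nM with a range from 5000 nM to 35000 nM allowed for the untested change.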

Compound 4, concentration for 50% growth inhibition: 21000 nM
For compound 4 the middle estimate is 1.5-fold (0.18 log units) below the measured one, within the range that was stated.
By their numbers in this assay, from the lowest: compounds 3, 1, 2 and 4 (each within the scatter of the next).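

Attaching 2,4,6-trimethylphenyl directly to the nitrogen, with no saturated chain carbon, keeps growth inhibition in this assay level with all three earlier compounds (a 1.9-fold higher number from compound 3 to compound 4 (0.28 log units; within the scatter)) (a 1.0-fold higher number from compound 2 to compound 4 (0.01 log units; within the scatter)) (a 1.1-fold higher number from compound 1 to compound 4 (0.05 log units; within the scatter)). This position therefore accepts the removal of the chain carbon together with the change of ring, with no shift beyond the scatter. No measurement at hand explains this result.

As far as these compounds go, whether any group on this nitrogen can move the number beyond the scatter remains open, for example a carboxylic acid or a longer chain such as 2-phenylethyl.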